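The source may report more compounds than this note shows. Statements on the series, on what has been measured and on what is new or still open speak of the compounds shown alone.

In a functional assay on CCRF-CEM cells (Homo sapiens) for cytotoxicity, in the absence of a further agent (on this read-out higher numbers stand for weaker inhibition and lower numbers for stronger inhibition), compound 1 `COC(=O)c1ccc(CN(CCCc2c(N)nc(N)nc2O)c2cc(F)cc(F)c2[N+](=O)[O-])cc1` reads > 100000 nM, and this value is a limit of the assay. Compound 2 `COC(=O)c1ccc(CN(CCCc2c(N)nc(N)nc2O)c2cc(F)c(F)cc2[N+](=O)[O-])cc1` gives 55000 nM and compound 3 `COC(=O)c1ccc(CN(CCCc2c(N)nc(N)nc2O)c2cc(F)ccc2[N+](=O)[O-])cc1` gives 43000 nM, so these two numbers sit within the scatter of each other. Compound 4 `Nc1nc(N)c(CCCNc2cc(F)c(F)cc2[N+](=O)[O-])c(O)n1` differs from compound 2 by hydrogen in place of 4-(methoxycarbonyl)benzyl on a nitrogen on an aromatic ring. The measured steps concern only fluoro on the aromatic ring. They are an at least 1.8-fold lower number from compound 1 to compound 2 (0.25 log units; that floor lies within the scatter), then an at least 2.3-fold lower number from compound 1 to compound 3 (0.36 log units; beyond the scatter), and finally a 1.3-fold lower number from compound 2 to compound 3 (0.11 log units; within the scatter). None of them touches that nitrogen, so they give neither a size nor a direction for this change, and the uncertainty is wide. No step beyond the scatter is therefore expected in this assay. The estimated step is a 1.1-fold higher number from compound 2 to compound 4 (0.04 log units; within the scatter). For compound 4 the expected value is 60000 nM, with an estimated range from 15000 nM to 200000 nM.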

Compound 4, half-maximal inhibitory concentration: > 100000 nM
Compound 4: only a limit was reported (the forecaster's own chance of this, stated with the estimate: 40%); middle value at least 1.6-fold (0.22 log units) from the limit.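

In this assay compound 4 gives > 100000 nM, and this value is a limit of the assay. Hydrogen in place of 4-(methoxycarbonyl)benzyl on the nitrogen brings an at least 1.8-fold higher number from compound 2 to compound 4 (0.25 log units; that floor lies within the scatter), the first reading at this position, which the fluoro steps never touched; the 4-(methoxycarbonyl)benzyl group is thus not shown to be needed for a reading beyond the scatter. The true size of the step stays unknown because the value for compound 4 is only a limit: the limit of > 100000 nM in this assay, at which 2 of the 4 values shown sit.

The compounds shown leave open whether the ester itself matters, since a carboxylic acid in its place or a plain benzyl group on this nitrogen would separate the ester from the ring. They also leave open how a longer chain on this nitrogen would read.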